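Moving the Chlorine on a Thiosemicarbazone Side Ring

A few compounds are considered here, and "the series" means these few. Any claim that something is new, unique, unknown or untested is made for them only; others in the source may bear on it.

Compound 1 `S=C(N/N=C/c1ccc2ccccc2n1)Nc1cccc(Cl)c1` is tested in a functional assay on SGC-7901 cells (Homo sapiens) for antiproliferative activity, read by sulforhodamine B assay, with a stated time of 72 h (a higher number here means a weaker inhibitor, a lower number a stronger inhibitor), and gives 61300 nM. Of the two numbers recorded, this is the higher one; compound 3 `CN(C)C(=S)N/N=C/c1ccc2ccccc2n1` gives 30 nM in this assay, and the gap between the two lies well beyond the scatter of repeated measurements. Compound 2 `Cc1csc2sc(/C=N/NC(N)=S)c(C)c12` gives only a limit in this assay, > 100000 nM, which is the edge of what the assay reports, as shown by the limit of > 100000 nM in this assay, at which 1 of the 3 values shown sits. The next compound, compound 4 `S=C(N/N=C/c1ccc2ccccc2n1)Nc1ccc(Cl)cc1`, is built from the same atoms as compound 1, joined differently: 4-chlorophenyl in place of 3-chlorophenyl on an amide-type nitrogen. Within the data shown here, no measured pair shows what such a rearrangement does, so the step has to be judged from the structures alone. Since only the chlorophenyl is altered and the rest of compound 1 is kept, the expected step from compound 1 to compound 4 is small, a 1.2-fold lower number from compound 1 to compound 4 (0.09 log units; within the scatter), without a clear direction beyond the scatter. The estimate for compound 4 in this assay is 50000 nM, with a range from 15000 nM to 150000 nM.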

Compound 4, half-maximal inhibitory concentration: 87600 nM
Beside the measured number, compound 4's estimate is 1.8-fold (0.24 log units) below it, within the range that was stated.
By their numbers in this assay, from the lowest: compound 3; then compounds 1 and 4 (each within the scatter of the next). At a limit, above all of these: compound 2.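

In this assay, moving the chlorine so that 4-chlorophenyl replaces 3-chlorophenyl on the amide-type nitrogen gives a 1.4-fold higher number from compound 1 to compound 4 (0.16 log units; within the scatter). Among these compounds, this is the first measured pair that differs in one place, and it shows that this change of chlorine position does not separate the two compounds beyond the usual scatter, so the assay gives no reason to prefer either chlorophenyl group. Nothing measured here offers an explanation for how closely the two numbers agree.

The pair covers only these two chlorophenyl groups on one shared core, so it sets no rule for other groups at this nitrogen. From the compounds shown here alone, whether an unsubstituted phenyl ring, or a phenyl ring carrying a methoxy group, an amine or a carboxylic acid in place of the chlorine, would give a different number remains open.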